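The source may report more compounds than this note shows. Statements on the series, on what has been measured and on what is new or still open speak of the compounds shown alone.

Measured so far:
Compound 1 `O=c1n(Cc2nc(-c3nccs3)cn2CCCCO)c2cnccc2n1C1CC1` gives 1.3 in a physicochemical assay for lipophilicity, measured as octanol-water partition, at pH 7.4; on this read-out lower numbers stand for lower lipophilicity and higher numbers for higher lipophilicity.
Compound 2 `COC(=O)N1CCC(n2c(=O)n(Cc3nc(C)c(C)n3CCCCO)c3cnccc32)CC1` gives -0.5 in this assay.

Among these two numbers, compound 1 stands highest; compound 2 lies well below it, and that gap is beyond the usual scatter of this kind of measurement. The two compounds differ from each other in several places at once, so their gap cannot be tied to any single change.

Compound 3 `Cc1nnc(-c2cn(CCCCO)c(Cn3c(=O)n(C4CC4)c4ccncc43)n2)s1` has not been measured. It differs from compound 1 in one place only: 5-methyl-1,3,4-thiadiazol-2-yl in place of 1,3-thiazol-2-yl on an aromatic carbon. Among the measured compounds shown here, no pair of measured compounds differs by a single change of this kind, so nothing measured here shows how large such a step tends to be. The leaving group and the entering group are both small five-membered aromatic rings of closely similar size, and the rest of the molecule stays as it is. On that basis only a small shift is expected, and it may not rise above the scatter at all. The expected step is a number 0.20 log units lower from compound 1 to compound 3 (within the scatter), a slight move downward at most. Compound 3 is therefore estimated at 1.1, with a likely range from 0.6 to 1.6.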

Compound 3, distribution coefficient: 0.9
Compound 3: middle estimate off by 0.20 log units, on the high side; measured number inside the range.
By their numbers in this assay, from the lowest: compound 2; then compound 3; then compound 1.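

Among the compounds shown here, replacing 1,3-thiazol-2-yl with 5-methyl-1,3,4-thiadiazol-2-yl gives the first reading of a single change in this assay, and the step is a number 0.40 log units lower from compound 1 to compound 3 (beyond the scatter) on this aromatic carbon. Although the two five-membered aromatic rings differ by only a few atoms, the step is modest but clear of the usual scatter, so this position does register a swap between closely related rings while the rest of compound 1 stays unchanged. No measured evidence here bears on why the number moves, so the step can be recorded but not explained.

Because the entering group differs from the leaving one both in its ring nitrogen count and in its methyl group, these compounds cannot show how much of the step belongs to each, and the unmethylated 1,3,4-thiadiazol-2-yl group would be the natural way to separate them. They also leave open how far the number would move with a quite different group on this carbon, such as a phenyl ring, an amine or a carboxylic acid, and whether the same swap would give a similar step on a different core.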